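A few compounds are considered here, and "the series" means these few. Any claim that something is new, unique, unknown or untested is made for them only; others in the source may bear on it.

Compound 1 `CC(=O)N1CCN(c2nc(=O)c3cc(C(F)(F)F)cc([N+](=O)[O-])c3s2)CC1` in a physicochemical assay for solubility, read by HPLC; a higher number here means a more soluble compound, a lower number a less soluble compound: 83.9 ug/mL
Compound 2 `CCCCC(=O)N1CCN(c2nc(=O)c3cc(C(F)(F)F)cc([N+](=O)[O-])c3s2)CC1` in this assay: 42.5 ug/mL
Compound 3 `O=C(C1CCCCC1)N1CCN(c2nc(=O)c3cc(C(F)(F)F)cc([N+](=O)[O-])c3s2)CC1` in this assay: 3.24 ug/mL

Compound 3 gives the lowest of the three numbers in this assay. Its nearest neighbour is compound 2, with a 13-fold lower number from compound 2 to compound 3 (1.12 log units; beyond the scatter), and the furthest is compound 1, with a 26-fold lower number from compound 1 to compound 3 (1.41 log units; beyond the scatter); both steps lie beyond the scatter, whereas a 2.0-fold lower number from compound 1 to compound 2 (0.30 log units; within the scatter) does not.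

Compound 4 `O=C(c1cccc(F)c1)N1CCN(c2nc(=O)c3cc(C(F)(F)F)cc([N+](=O)[O-])c3s2)CC1` differs from compound 3 in one place: 3-fluorophenyl in place of cyclohexyl on a carbonyl carbon. For the measured compounds named here, no measured step involves an aromatic ring on this carbonyl carbon, so none bears on the change directly. Going by the values given here, the only guidance comes from the two steps in which cyclohexyl entered, a 26-fold lower number from compound 1 to compound 3 (1.41 log units; beyond the scatter) and a 13-fold lower number from compound 2 to compound 3 (1.12 log units; beyond the scatter), which show that this group carries the low number of compound 3, and from a 2.0-fold lower number from compound 1 to compound 2 (0.30 log units; within the scatter), which shows that lengthening a chain changed little. Whether exchanging the cyclohexyl for a 3-fluorophenyl undoes part of that fall cannot be read from these three compounds alone.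

On that footing, compound 4 is expected to show a small rise, a 1.9-fold higher number from compound 3 to compound 4 (0.27 log units; within the scatter), which may well remain within the scatter. The estimate for compound 4 in this assay is 6 ug/mL, with a range from 2 ug/mL to 20 ug/mL.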

Compound 4, solubility: 0.2 ug/mL
For compound 4 the middle estimate is 30-fold (1.48 log units) above the measured one; the whole stated range lies above it.
By their numbers in this assay, from the lowest: compound 4; then compound 3; then compounds 2 and 1 (each within the scatter of the next).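

For the compounds shown here, this is the first aromatic ring on this carbonyl carbon, and in this assay it extends the fall seen with cyclohexyl rather than undoing part of it, with a 16-fold lower number from compound 3 to compound 4 (1.21 log units; beyond the scatter). Measured against the chain-bearing compounds, the same change gives a 210-fold lower number from compound 2 to compound 4 (2.33 log units; beyond the scatter) and a 420-fold lower number from compound 1 to compound 4 (2.62 log units; beyond the scatter), so among these four compounds, which differ only in the group on this carbonyl carbon, the two ring-bearing compounds give the lowest numbers and the position proves far more sensitive than the lengthening of the chain suggested. Cyclohexyl and 3-fluorophenyl have equal counts of hydrogen-bond donors and acceptors and neither carries a net charge, leaving the aromatic ring and the fluorine as the computed differences, and no measurement here explains the step.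

Going by these compounds, what a plain phenyl would give on this carbonyl carbon remains open, so the shares of the aromatic ring and of the fluorine stay unseparated. Also open, on these data alone, is whether a pyridyl ring, or an amine carried on the ring, would raise the number again.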